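A few compounds are considered here, and "the series" means these few. Any claim that something is new, unique, unknown or untested is made for them only; others in the source may bear on it.

Measured in an ADME assay on H9 cells (Homo sapiens) for cytotoxicity, read by XTT assay, with a stated time of 6 days; a higher number here means that more compound is tolerated, a lower number that less compound is tolerated:
- compound 1 `Cc1cc(Br)cc(C)c1Oc1ccc([N+](=O)[O-])c(Nc2ccc(C#N)cc2)c1`: > 57000 nM (a limit)
- compound 2 `Cc1cc(C#N)cc(C)c1Oc1cc(Nc2ccc(C#N)cc2)c([N+](=O)[O-])cc1[N+](=O)[O-]`: > 58200 nM (a limit)
- compound 3 `Cc1cc(Br)cc(C)c1Oc1cc(Nc2ccc(C#N)cc2)c(N)cc1[N+](=O)[O-]`: 45500 nM; 36400 nM (2 entries) (two entries)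

Compound 2 has no number in this assay, only the limit > 58200 nM. It therefore cannot be ranked exactly against the other two compounds, and compound 3 is the only one of the three with numerical entries.

Not yet measured is compound 4 `Cc1cc(Br)cc(C)c1Oc1cc(Nc2ccc(C#N)cc2)c([N+](=O)[O-])cc1[N+](=O)[O-]`. It keeps the rest of compound 2 and has bromo in place of cyano on an aromatic carbon, the change from 4-cyano-2,6-dimethylphenyl to 4-bromo-2,6-dimethylphenyl (bromo in place of cyano on an aromatic carbon). Among the measured compounds shown here, no measured pair isolates this change, so the expectation rests on the two measured compounds that carry the same bromo group, although both differ from compound 4 elsewhere.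

Compound 1 gives only the limit > 57000 nM. Compound 3 gives 45500 nM; 36400 nM (2 entries). On these results, no shift beyond the scatter is expected, and the estimated step of an at least 1.2-fold lower number from compound 2 to compound 4 (0.08 log units; that floor lies within the scatter) is read in that light.

The estimate for compound 4 is 48000 nM, with an expected range of 18000 nM to 60000 nM. A result reported only as a limit is also quite possible.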

Compound 4, half-maximal cytotoxic concentration: > 51700 nM
Compound 4: a limit, no number; the forecaster's own chance of this, stated with the estimate: 55%; at least 1.0-fold (0.03 log units) between middle value and limit.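

In this assay compound 4 gives only a limit, > 51700 nM. Compound 1 and compound 2 also carry only limits, so neither step to compound 4 can be read. The compounds shown leave open whether bromo in place of cyano, or nitro in place of hydrogen, changes the half-maximal cytotoxic concentration at all.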